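The compounds below may be only part of what the source reports. "The series", "measured", "known", "first", "only" and "open" are said of these compounds alone.

Two compounds share one core and differ only in the group on the aromatic ring at the far end of the chain. Compound 1, `CC1=C(/C=C/C(=O)/C=C/c2cccc(C(F)(F)F)c2)C(C)(C)CCC1O`, carries a trifluoromethyl there, and in a functional assay on LNCaP C4-2B cells (Homo sapiens) for cytotoxicity, read by MTT assay, with a stated time of 72 h (on this read-out lower numbers stand for stronger inhibition and higher numbers for weaker inhibition), compound 1 gives 1400 nM. Compound 2, `CC1=C(/C=C/C(=O)/C=C/c2ccc(F)cc2)C(C)(C)CCC1O`, carries a fluoro group instead, and in this assay compound 2 gives 4000 nM. Among the compounds with values here, of the two numbers so far, compound 2 has the higher one, and its distance from compound 1 lies beyond the scatter, so compound 2 is the weaker of the pair on this read-out.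

Compound 3, `CC1=C(/C=C/C(=O)/C=C/c2ccc(F)c(C(F)(F)F)c2)C(C)(C)CCC1O`, keeps the fluoro group of compound 2 and adds a second group: trifluoromethyl in place of hydrogen on an aromatic carbon, ortho to that fluoro group. Within the data shown here, no step between two measured compounds matches this change, so the expectation rests only on the pair at hand. A trifluoromethyl on this ring is expected to pull the number down, because compound 1 gives 1400 nM, a lower number than compound 2. The step from compound 2 to compound 3 is therefore expected to be a moderate drop, a 2.0-fold lower number from compound 2 to compound 3 (0.30 log units; within the scatter), and compound 3 is estimated at 2000 nM, within a range from 800 nM to 5000 nM.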

Compound 3, half-maximal inhibitory concentration: 7300 nM
Beside the measured number, compound 3's estimate is 3.7-fold (0.56 log units) below it; the measured number lies above the stated range.
By their numbers in this assay, from the lowest: compound 1; then compounds 2 and 3 (each within the scatter of the next).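

In this assay, placing a trifluoromethyl ortho to a fluoro group gives a 1.8-fold higher number from compound 2 to compound 3 (0.26 log units; within the scatter), so compound 2 and compound 3 cannot be told apart on this read-out, and this position tolerates the added group without a clear gain or loss. The change that does register is a different one: fluoro in place of hydrogen on an aromatic carbon gives a 5.2-fold higher number from compound 1 to compound 3 (0.72 log units; beyond the scatter), so with the trifluoromethyl already on the ring, adding the fluoro group gives a modest but real move toward weaker inhibition. Nothing available explains why the two groups behave this way together.

The compounds shown leave open whether this position accepts any group equally, or whether something of another kind ortho to the fluoro group, such as an amine or a carboxylic acid, would separate clearly from compound 2. They also leave open whether a smaller group such as chlorine or methyl in place of that trifluoromethyl would give a number beyond the scatter.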